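The compounds below may be only part of what the source reports. "The series", "measured", "known", "first", "only" and "open" are said of these compounds alone.

Measured compounds:

Compound 1, `Cc1c(O)ccc2c1[C@H](Cn1cc(-c3ccc(F)cc3)nn1)[C@@]13CC(=O)[C@@](C)(CC[C@@H]21)C3` — in a functional assay on A549 cells (Homo sapiens) for cytotoxicity, read by MTT assay, with a stated time of 4 days (on this read-out lower numbers stand for stronger inhibition and higher numbers for weaker inhibition), compound 1 gives > 20000 nM, which is a limit of the assay and not a number.
Compound 2, `C=C1C[C@]23C[C@@]1(O)CC[C@H]2c1ccc(O)c(C)c1[C@@H]3Cn1cc(-c2ccccc2)nn1` — in this assay compound 2 gives > 20000 nM, again a limit rather than a number.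
Compound 3, `Cc1ccc(S(=O)(=O)Oc2ccc3c(c2C)[C@H](Cn2cc(-c4ccc(F)cc4)nn2)[C@@]24CC(=O)[C@@](C)(CC[C@@H]32)C4)cc1` — in this assay compound 3 gives > 20000 nM, again a limit rather than a number.

All three measured compounds thus sit at the same place: the limit of > 20000 nM in this assay, at which 3 of the 3 values shown sit. The change from compound 1 to compound 3 is (4-methylphenyl)sulfonyl in place of hydrogen on an oxygen on an aromatic ring. The step it made is a step that the two limits leave unreadable from compound 1 to compound 3; both ends are limits, so the size of this step cannot be read.

Compound 2 has a different core from compound 1; the difference between the two cores is not broken down here. Compound 4, `C=C1C[C@]23C[C@@]1(O)CC[C@H]2c1ccc(OS(=O)(=O)c2ccc(C)cc2)c(C)c1[C@@H]3Cn1cc(-c2ccccc2)nn1`, is not yet measured. It arises from compound 2 by (4-methylphenyl)sulfonyl in place of hydrogen on an oxygen on an aromatic ring, the same change that turns compound 1 into compound 3, at a place described in the same words.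

For compound 4 the expected step is a step that the limit leaves unreadable from compound 2 to compound 4. This expectation rests on compound 2, which in this assay gives > 20000 nM, a limit. It also rests on the same change leaving compound 3 at > 20000 nM, likewise a limit. Compound 4 is therefore expected to give about 30000 nM, estimated between 10000 nM and 100000 nM, and most probably only a limit will be reported again.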

Compound 4, half-maximal inhibitory concentration: > 20000 nM
Compound 4: no number, only a limit; the forecaster's own chance of this, stated with the estimate: 85%; the middle value is on the limit's open side.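

No new step can be read from compound 2 to compound 4, since both stop at a limit of the assay and not at a number. All the compounds shown share that position: the limit of > 20000 nM in this assay, at which 4 of the 4 values shown sit. As far as these compounds go, what stays open is whether any change to these cores can give a measurable value in this assay and how strongly the (4-methylphenyl)sulfonyl group shifts that value.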